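The source may hold more compounds than are shown below. What is called first, only, known or untested is meant among the compounds shown, and "the series" means these compounds.

Working notes on the series. Compound 3 `c1cn2cc(-c3ccsc3)nc(-c3ccc4ncn(C5CCCCC5)c4c3)c2n1` carries a thiophen-3-yl group on the shared core; in a functional assay on MDA-MB-231 cells (Homo sapiens) for inhibition, read by sulforhodamine B assay, with a stated time of 48 h, tested at 10 uM (on this read-out lower numbers stand for less inhibition and higher numbers for more inhibition at the one concentration tested (going by the name of the read-out)), compound 3 gives 1.35%, the lowest of the three numbers measured. Compound 1 `COc1ccc(-c2cn3ccnc3c(-c3ccc4ncn(C5CCCCC5)c4c3)n2)cc1`, with 4-methoxyphenyl at the same place, gives 71.1%, and compound 2 `Fc1ccc(-c2cn3ccnc3c(-c3ccc4ncn(C5CCCCC5)c4c3)n2)cc1`, with 4-fluorophenyl, gives 15.8%. Both steps into compound 3 were downward: a number 69.8 percentage points lower from compound 1 to compound 3 (beyond the scatter) and a number 14.5 percentage points lower from compound 2 to compound 3 (beyond the scatter). The remaining measured step, a number 55.3 percentage points lower from compound 1 to compound 2 (beyond the scatter), shows how strongly the number depends on which group sits on the phenyl ring.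

Compound 4 `CC(=O)c1ccc(-c2cn3ccnc3c(-c3ccc4ncn(C5CCCCC5)c4c3)n2)cc1` is not yet measured. It differs from compound 3 thus: 4-acetylphenyl in place of thiophen-3-yl on an aromatic carbon. The two steps that bear on it both run from a substituted phenyl to thiophen-3-yl, one large and one modest, and both lowered the number; going back to a substituted phenyl is therefore expected to raise it. Among the compounds with values here, the size is uncertain, since the two substituted phenyls measured gave numbers as far apart as those of compound 1 and compound 2, and no acetyl analogue has been measured. The step is expected to be upward, a number 33.7 percentage points higher from compound 3 to compound 4 (beyond the scatter). Compound 4 is accordingly estimated at 35%, within 5% to 75%.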

Compound 4, a percentage reported as inhibition, at one concentration (the size of the read-out at that concentration, not a potency): 7.65%
The estimate for compound 4 lay 27.4 percentage points above the measured number, and the stated range covers the measured number.
By their numbers in this assay, from the lowest: compounds 3, 4 and 2 (each within the scatter of the next, the first and the last beyond it); then compound 1.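

In this assay, putting a substituted phenyl back at this position does not by itself bring the number back: the change gives a number 6.3 percentage points higher from compound 3 to compound 4 (within the scatter) and so leaves 4-acetylphenyl and thiophen-3-yl indistinguishable here. On the phenyl ring, acetyl in place of fluoro gives a number 8.2 percentage points lower from compound 2 to compound 4 (within the scatter) and does not separate these two compounds, whereas acetyl in place of methoxy gives a number 63.5 percentage points lower from compound 1 to compound 4 (beyond the scatter) and marks a clear gap. Compound 4 therefore shows that the high number of compound 1 does not extend to every substituted phenyl in this set, since 4-acetylphenyl, like 4-fluorophenyl, stays far from 4-methoxyphenyl.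

Still open, from the compounds shown here alone, is whether the high number is tied to methoxy itself or would also appear with a different group on the phenyl ring, such as ethoxy, hydroxy or dimethylamino, or with methoxy moved elsewhere on that ring. Nothing measured on these groups is at hand to explain the separation of compound 1 from compound 4.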